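The source may report more compounds than this note shows. Statements on the series, on what has been measured and on what is new or still open speak of the compounds shown alone.

Measured so far in an assay on CHO cells for agonist activity at Neuronal acetylcholine receptor; alpha3/alpha6/beta2/beta3 (Homo sapiens), read by FLIPR and calcium flux; on this read-out higher numbers stand for larger maximal responses and lower numbers for smaller maximal responses:
- compound 1 `CC(C)C(=O)N1CC2CC(C1)N2` gives 45%
- compound 2 `O=C(C1CCCC1)N1CC2CC(C1)N2` gives 62%
- compound 3 `O=C(C1CC=CC1)N1CC2CC(C1)N2` gives 99%

Compound 1 stands lowest of the three numbers. Its nearest neighbour is compound 2, whose value is higher by an amount beyond the scatter; compound 3 is further away still, also beyond the scatter. Both compounds above compound 1 carry a ring on the carbonyl carbon in place of the isopropyl, but two compounds are too few to call this a trend.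

The next compound, compound 4 `O=C([C@@H]1C[C@H]1F)N1CC2CC(C1)N2`, is not yet measured in this assay. It differs from compound 1 as follows: 2-fluorocyclopropyl in place of isopropyl on a carbonyl carbon. For the measured compounds named here, no step between two measured compounds maps onto this change, so the expectation rests only on the values of compounds 1, 2 and 3. A moderate rise is expected, since the ring-bearing compounds 2 and 3 sit above compound 1 in this assay, giving an expected step of a number 15 percentage points higher from compound 1 to compound 4 (beyond the scatter). Compound 4 is therefore estimated at 60%, within a range from 35% to 90%.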

Compound 4, largest response reached (Emax), in percent of the reference or control that the assay uses: 130%
The estimate for compound 4 lay 70 percentage points below the measured number, outside the stated range (above it).
By their numbers in this assay, from the lowest: compound 1; then compound 2; then compound 3; then compound 4.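

In this assay, 2-fluorocyclopropyl in place of isopropyl on the carbonyl carbon gives a large rise, a number 85 percentage points higher from compound 1 to compound 4 (beyond the scatter). Compound 3 gives 99% and compound 4 gives 130%, so the response at this position does not stop at the level of compound 3, and a three-membered ring can carry it that far, where the earlier ring-bearing compounds held larger rings. Nothing available accounts for the size of this step.

The compounds shown do not separate the share of the fluorine from that of the three-membered ring; plain cyclopropyl on the same carbonyl carbon would address that. Also open, going by these compounds, is how 2-fluorocyclopropyl with the opposite arrangement at its two defined stereocentres would compare with compound 4 on the shared core.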